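Swapping the ring on the nitrogen: from dimethoxy to chloro-ester

The source may hold more compounds than are shown below. What is called first, only, known or untested is meant among the compounds shown, and "the series" means these compounds.

Three compounds have been measured in a functional assay on SNU-638 cells (Homo sapiens) for cytotoxicity, read by sulforhodamine B assay, with a stated time of 72 h; a higher number here means a weaker inhibitor, a lower number a stronger inhibitor:

compound 1, `CCS(=O)(=O)Nc1cc(-c2ccc3ncnc(Nc4ccc(F)cc4)c3c2)cnc1OC`, gives 2400 nM
compound 2, `CCS(=O)(=O)Nc1cc(-c2ccc3ncnc(Nc4ccc(OC)cc4)c3c2)cnc1OC`, gives 3970 nM
compound 3, `CCS(=O)(=O)Nc1cc(-c2ccc3ncnc(Nc4ccc(OC)c(OC)c4)c3c2)cnc1OC`, gives 1680 nM

All three share one core and differ only in the ring carried on the nitrogen. Compound 3 has the lowest of the three numbers in this assay, but its gap to compound 1 is within the scatter, as a 1.4-fold lower number from compound 1 to compound 3 (0.15 log units; within the scatter) shows, while a 2.4-fold lower number from compound 2 to compound 3 (0.37 log units; beyond the scatter) is beyond it. The step of a 1.7-fold higher number from compound 1 to compound 2 (0.22 log units; within the scatter) is also within the scatter, so the whole set spans a narrow band.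

Compound 4, `CCS(=O)(=O)Nc1cc(-c2ccc3ncnc(Nc4ccc(Cl)c(C(=O)OC)c4)c3c2)cnc1OC`, has not yet been measured. The change is 4-chloro-3-(methoxycarbonyl)phenyl in place of 3,4-dimethoxyphenyl on a nitrogen on an aromatic ring. For the measured compounds named here, none of the measured steps involves a chloro or a methoxycarbonyl group; they only show that exchanging fluoro for methoxy, or adding a second methoxy, moves the number by little. With nothing closer to rest on, the step from compound 3 to compound 4 is expected to be small, a 1.2-fold higher number from compound 3 to compound 4 (0.08 log units; within the scatter), with no confident direction. Compound 4 is therefore estimated at 2000 nM, with a range from 700 nM to 6000 nM.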

Compound 4, half-maximal inhibitory concentration: 2200 nM
Estimate against measurement, compound 4: 1.1-fold (0.04 log units) below, within the range that was stated.
By their numbers in this assay, from the lowest: compounds 3, 4, 1 and 2 (each within the scatter of the next, the first and the last beyond it).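

For the compounds shown here, compound 4 brings a chloro group and a methoxycarbonyl group onto the ring on the nitrogen, and neither group appears in the earlier compounds, yet in this assay the result stays inside the same narrow band. The steps read a 1.3-fold higher number from compound 3 to compound 4 (0.12 log units; within the scatter) and a 1.1-fold lower number from compound 1 to compound 4 (0.04 log units; within the scatter) and also a 1.8-fold lower number from compound 2 to compound 4 (0.26 log units; within the scatter) and so compound 4 cannot be told apart from any of the other three. This position therefore tolerates a 4-chloro-3-(methoxycarbonyl)phenyl ring as well as the fluoro and methoxy rings, and nothing shown explains why so different a pair of groups moves the number so little.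

The compounds shown leave open how the chloro group and the methoxycarbonyl group would each read alone on this ring, as the two enter together in compound 4. Also open, on these data alone, is what an amine or a carboxylic acid on this ring would do, or a longer chain in place of the methyl of the ester, and whether any such group could move the number out of this band.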